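Trifluoromethyl for Fluoro on a Sulfonyl-Bearing Imidazole Series

The compounds below may be only part of what the source reports. "The series", "measured", "known", "first", "only" and "open" are said of these compounds alone.

Measured compounds:
Compound 1, `Cc1ccc(-c2nn(-c3ccccc3)cc2-c2nc3ccccc3n2S(=O)(=O)c2ccc(F)cc2)cc1`: 167000 nM
Compound 2, `Cc1ccc(-c2nn(-c3ccccc3)cc2-c2nc3ccccc3n2S(=O)(=O)c2ccc(C(F)(F)F)cc2)cc1`: 89300 nM
Compound 3, `O=S(=O)(c1ccccc1)n1c(-c2cn(-c3ccccc3)nc2-c2ccc(F)cc2)nc2ccccc21`: 231000 nM

The three compounds were measured in an ADME assay on cells (Hepatocyte, Mus musculus) for cytotoxicity, read by MTT assay, with a stated time of 24 h; a higher number here means that more compound is tolerated, a lower number that less compound is tolerated. Compound 1 gives 167000 nM and compound 2 gives 89300 nM; the two differ by trifluoromethyl in place of fluoro on an aromatic carbon, and that change gave a 1.9-fold lower number from compound 1 to compound 2 (0.27 log units; within the scatter). Compound 3, a member of a different core, gives 231000 nM; the difference between the core of compound 3 and the core of compound 1 is not broken down here. Compound 3 and compound 1 sit within the scatter of each other, while the number for compound 3 stands beyond the scatter from that of compound 2.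

Compound 4, `O=S(=O)(c1ccccc1)n1c(-c2cn(-c3ccccc3)nc2-c2ccc(C(F)(F)F)cc2)nc2ccccc21`, has not yet been measured in this assay. It differs from compound 3 by trifluoromethyl in place of fluoro on an aromatic carbon, the same change, in the same place, as from compound 1 to compound 2. From compound 3 the expected step is a 1.8-fold lower number from compound 3 to compound 4 (0.27 log units; within the scatter), because the same change gave a 1.9-fold lower number from compound 1 to compound 2 (0.27 log units; within the scatter) on the other core. The expectation rests on that single earlier instance and on nothing else, since only two pairs of this kind occur among the compounds shown. Compound 4 is therefore expected to give about 125000 nM in this assay, estimated to lie between 60000 nM and 260000 nM.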

Compound 4, half-maximal cytotoxic concentration: 186000 nM
Compound 4: middle estimate off by 1.5-fold (0.17 log units), on the low side; the range from low to high includes it.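

In this assay, for the compounds shown here, trifluoromethyl in place of fluoro gave a 1.2-fold lower number from compound 3 to compound 4 (0.09 log units; within the scatter), so on this core the change produced no step that stands out from repeated measurement. Set beside the earlier instance, the two steps cannot be told apart: the same change on two cores in this assay, a 1.9-fold lower number (0.27 log units; within the scatter) from compound 1 to compound 2 and a 1.2-fold lower number (0.09 log units; within the scatter) from compound 3 to compound 4, 1.5-fold (0.18 log units) apart, within the scatter of two such steps. This shows that, across these two pairs, the change carried from one core to the other without any detectable difference in the size of its step, but it does not show that the change has a real effect on the number on either core, nor that the two cores respond identically, and two pairs within the scatter cannot establish a rule for the series.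

The compounds shown carry only fluoro or trifluoromethyl at the changed place, so it remains open whether an amine, a carboxylic acid or a longer chain there would give a step beyond the scatter, and whether such a step would carry between the cores. From the compounds shown here alone, it also remains open whether trifluoromethyl in place of fluoro would behave the same way on a third core, as the evidence here extends only to the core of compound 1 and the core of compound 3.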